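Pyrazoline ring nitrogen: acetyl exchanged for (4-methylphenyl)sulfonyl

The compounds below may be only part of what the source reports. "The series", "measured", "known", "first", "only" and "open" are said of these compounds alone.

Measured compounds:
compound 1 `CC(=O)N1N=C(c2ccc(N3CCN(C)CC3)cc2)CC1c1ccc(N(C)C)cc1` — -0.8%
compound 2 `CC(=O)N1N=C(c2ccc(-n3cncn3)cc2)CC1c1ccc(N(C)C)cc1` — 11%
compound 3 `CC(=O)N1N=C(c2ccc(-n3ccnc3)cc2)CC1c1ccc(N(C)C)cc1` — -9.7%

In a functional assay on HCC1806 cells (Homo sapiens) for inhibition, read by sulforhodamine B assay, tested at 10 uM (a lower number here means less inhibition, a higher number more inhibition at the concentration tested (going by the name of the read-out)), compound 3 gives -9.7%, the lowest of the three numbers. Compound 1 stands closest, a gap within the scatter a number 8.9 percentage points lower from compound 1 to compound 3 (within the scatter); compound 2 is furthest, since the step of a number 20.7 percentage points lower from compound 2 to compound 3 (beyond the scatter) lies beyond the scatter. Compound 4 `Cc1ccc(S(=O)(=O)N2N=C(c3ccc(-n4ccnc4)cc3)CC2c2ccc(N(C)C)cc2)cc1` differs from compound 3 by (4-methylphenyl)sulfonyl in place of acetyl on an amine nitrogen in a ring. Going by the values given here, all measured steps concern the group on the aromatic carbon, including a number 11.8 percentage points higher from compound 1 to compound 2 (beyond the scatter); none touches the ring nitrogen, so no measured step bears directly on this change. Compound 3 is therefore expected to keep roughly its value in compound 4, with a number 9.7 percentage points higher from compound 3 to compound 4 (within the scatter) anticipated as no step beyond the scatter. Compound 4 is estimated at 0%, in the range -15% to 20%.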

Compound 4, a percentage reported as inhibition, at one concentration (the size of the read-out at that concentration, not a potency): 66%
The estimate for compound 4 lay 66 percentage points below the measured number, outside the stated range (above it).
By their numbers in this assay, from the lowest: compounds 3 and 1 (each within the scatter of the next); then compound 2; then compound 4.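

In this assay the amine nitrogen in the five-membered ring proves far more responsive than the aromatic carbon varied earlier: (4-methylphenyl)sulfonyl in place of acetyl gives a number 75.7 percentage points higher from compound 3 to compound 4 (beyond the scatter), a larger step than any measured at that carbon. Nothing on hand explains this step. Going by these compounds, whether it comes from the sulfonyl or from the aromatic ring stays open; a methylsulfonyl or benzoyl group on that nitrogen would separate the two. Also open, on these data alone, is whether (4-methylphenyl)sulfonyl gives a similar step alongside 1H-1,2,4-triazol-1-yl or 4-methylpiperazin-1-yl.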